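The compounds below may be only part of what the source reports. "The series", "measured", "known", "first", "only" and "open" are said of these compounds alone.

Working notes on a functional assay on HOS-TE85 cells (Homo sapiens) for inhibition, read by CCK-8 assay, with a stated time of 72 h; on this read-out higher numbers stand for weaker inhibition and lower numbers for stronger inhibition. Compound 1 `COc1ccccc1N1C(=O)CSC1c1cccc(C(=O)NCCCCc2ccc(Cl)cc2)c1` gives 78.6 nM in this assay. Compound 3 `O=C(NCCCCc1ccccc1)c1cccc(C2OCC(=O)N2c2cccc(F)c2)c1` gives 320 nM. Compound 2 `CCN(CC)c1ccc(N2C(=O)CSC2c2cccc(C(=O)NCCCCc3ccccc3)c2)cc1` is reported only as a limit of this assay, > 1000 nM, not as a number; it sits at the limit of > 1000 nM in this assay, at which 1 of the 3 values shown sits. On the numbers shown, compound 2 therefore stands apart as the one compound returned at the limit, while compound 1 and compound 3 carry measured values.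

The step from compound 2 to compound 4 `COc1ccc(F)cc1N1C(=O)CSC1c1cccc(C(=O)NCCCCc2ccccc2)c1` is this change: 5-fluoro-2-methoxyphenyl in place of 4-(diethylamino)phenyl on an amide-type nitrogen in a ring. Among the measured compounds shown here, no step between two measured compounds covers it, so no measured size is attached to it. Compound 4 is closest in structure to compound 1, which gives 78.6 nM in this assay, and that value lies well below the top of the range. The expected direction is therefore toward stronger inhibition, beyond the scatter. Compound 2 stands only at a limit; the exact size of the expected step is open. Compound 4 is expected at 150 nM, with a range of 50 nM to 500 nM. The estimated step is an at least 6.6-fold lower number from compound 2 to compound 4 (0.82 log units; beyond the scatter).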

Compound 4, half-maximal inhibitory concentration: 8.8 nM
For compound 4 the middle estimate is 17-fold (1.23 log units) above the measured one; measured number outside the range, below it.
By their numbers in this assay, from the lowest: compound 4; then compound 1; then compound 3. At a limit, above all of these: compound 2.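

Among the compounds shown here, until this result, no step between measured compounds covered the group on the amide-type nitrogen in the ring. In this assay, 5-fluoro-2-methoxyphenyl in place of 4-(diethylamino)phenyl at this one place now gives an at least 110-fold lower number from compound 2 to compound 4 (2.05 log units; beyond the scatter), showing that this position alone can move the read-out well beyond the scatter on the shared core. The step has only a lower bound on its size, as compound 2 is held at a limit of the assay: the limit of > 1000 nM in this assay, at which 1 of the 4 values shown sits.

For the compounds shown here, the single exchange replaces the whole aryl group, so the separate contributions of the fluoro and methoxy substituents cannot be read from it. As far as these compounds go, how an unsubstituted phenyl or a phenyl bearing a carboxylic acid would behave at this place remains open, as does whether the step holds with the chain or ring atoms changed elsewhere.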